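Aromatic amine in place of cyclopentyl: compound 4

The source may report more compounds than this note shows. Statements on the series, on what has been measured and on what is new or still open speak of the compounds shown alone.

Within the data shown here, in a functional assay on MCF7 cells (Homo sapiens) for antiproliferative activity, read by MTT assay, with a stated time of 72 h (on this read-out lower numbers stand for stronger inhibition and higher numbers for weaker inhibition), compound 1 `O=C(Nc1ccc(Nc2nccc(NC3CCCC3)n2)cc1)Nc1ccc(Cl)c(C(F)(F)F)c1` gives 2330 nM, the lowest of the two actual numbers so far. Compound 3 `O=C(Nc1ccc(Nc2nccc(Nc3ccc(Cl)cc3)n2)cc1)Nc1ccc(Cl)c(C(F)(F)F)c1` follows at 12800 nM. Compound 2 `O=C(Nc1ccc(Nc2nccc(Nc3ccccc3)n2)cc1)Nc1ccc(Cl)c(C(F)(F)F)c1` reads > 50000 nM, which is a limit and not a number.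

Compound 4 `Cn1cc(Nc2ccnc(Nc3ccc(NC(=O)Nc4ccc(Cl)c(C(F)(F)F)c4)cc3)n2)cn1` carries 1-methyl-1H-pyrazol-4-yl in place of cyclopentyl on a nitrogen on an aromatic ring. Two measured steps also replace cyclopentyl with an aromatic ring, and both run to higher numbers: an at least 21-fold higher number from compound 1 to compound 2 (1.33 log units; beyond the scatter) is large and a 5.5-fold higher number from compound 1 to compound 3 (0.74 log units; beyond the scatter) is modest. The ring's substituent matters as well, as an at least 3.9-fold lower number from compound 2 to compound 3 (0.59 log units; beyond the scatter) shows. Among the measured compounds shown here, neither ring matches the one in compound 4, so the size of the step stays uncertain.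

A modest to large rise in the number is therefore expected in this assay. The expected step is a 5.2-fold higher number from compound 1 to compound 4 (0.71 log units; beyond the scatter). For compound 4 the estimated value is 12000 nM, with an expected range from 3000 nM to 50000 nM.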

Compound 4, half-maximal inhibitory concentration: 9770 nM
Compound 4: middle estimate off by 1.2-fold (0.09 log units), on the high side; measured number inside the range.
By their numbers in this assay, from the lowest: compound 1; then compounds 4 and 3 (each within the scatter of the next). At a limit, above all of these: compound 2.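

Exchanging cyclopentyl for 1-methyl-1H-pyrazol-4-yl gives a 4.2-fold higher number from compound 1 to compound 4 (0.62 log units; beyond the scatter) and so extends the trend to a five-membered aromatic ring with hetero atoms: all three aromatic groups shown on this nitrogen read higher than cyclopentyl, with no compound shown going against this. The 4-chlorophenyl and 1-methyl-1H-pyrazol-4-yl groups cannot be told apart here, with a 1.3-fold lower number from compound 3 to compound 4 (0.12 log units; within the scatter) as the printed step. Compound 2 stands at a limit and not at a number, which leaves an at least 5.1-fold lower number from compound 2 to compound 4 (0.70 log units; beyond the scatter) as a bound only, and the phenyl group alone among the three sits there: the limit of > 50000 nM in this assay, at which 1 of the 4 values shown sits.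

Open, on these data alone, is whether a saturated ring such as cyclohexyl or piperidine, or an open chain such as isopropyl, would keep the lower number of compound 1. No compound shown isolates the methyl of 1-methyl-1H-pyrazol-4-yl, so its share stays unknown.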